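This account rests on a few compounds, and the source may have more. Where it says the series, first, only, none or still open, it means among the compounds named here.

Working notes on the series, read in a functional assay on MIA PaCa-2 cells (Homo sapiens) for cytotoxicity, read by MTT assay, with a stated time of 72 h; a higher number here means a weaker inhibitor, a lower number a stronger inhibitor. Compound 1 `COC1=CC(=O)c2c(COc3ccccc3)c(C)n(C)c2C1=O` gives 409 nM, compound 2 `COC1=CC(=O)c2c(COc3ccc(C#N)cc3)c(C)n(C)c2C1=O` gives 192 nM, and compound 3 `COC1=CC(=O)c2c(COc3ccc(C(F)(F)F)cc3)c(C)n(C)c2C1=O` gives 311 nM. Two steps fix the standing of compound 2: a 2.1-fold lower number from compound 1 to compound 2 (0.33 log units; beyond the scatter), and a 1.6-fold higher number from compound 2 to compound 3 (0.21 log units; within the scatter). It therefore separates from compound 1 but not from compound 3. The remaining step, a 1.3-fold lower number from compound 1 to compound 3 (0.12 log units; within the scatter), also stays inside the scatter.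

Compound 4 `COC1=CC(=O)c2c(COc3ccccn3)c(C)n(C)c2C1=O` has not yet been measured. Its change is pyridin-2-yl in place of 4-cyanophenyl on an oxygen on a saturated carbon. Among the measured compounds shown here, no measured step introduces a ring nitrogen, so that part of the change has no direct guide. Like compound 1, compound 4 carries no cyano group, and the step that added this group was a 2.1-fold lower number from compound 1 to compound 2 (0.33 log units; beyond the scatter). Undoing that modest step suggests a modest rise in this assay, towards the value of compound 1 at 409 nM, with wide uncertainty.

For compound 4 the estimated value is 430 nM, with an expected range of 170 nM to 1100 nM. The expected change is a 2.2-fold higher number from compound 2 to compound 4 (0.35 log units; beyond the scatter).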

Compound 4, half-maximal inhibitory concentration: 2390 nM
Estimate against measurement, compound 4: 5.6-fold (0.74 log units) below; measured number above the stated range.
By their numbers in this assay, from the lowest: compounds 2, 3 and 1 (each within the scatter of the next, the first and the last beyond it); then compound 4.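

Changing the ring on the ether oxygen moves the number in this assay far more than changing the substituent on the phenyl ring does: pyridin-2-yl gives a 12-fold higher number from compound 2 to compound 4 (1.10 log units; beyond the scatter) and a 5.8-fold higher number from compound 1 to compound 4 (0.77 log units; beyond the scatter). The second step involves no nitrile, so the rise seen with compound 4 is not accounted for by the absence of that group alone, and both steps exceed every step among compounds 1, 2 and 3. Nothing available explains why this ring replacement has so large an effect in this series.

On these data alone, whether a nitrile or trifluoromethyl group on the pyridin-2-yl ring would bring the number back towards that of compound 2 remains open. Also open, as far as these compounds go, is how a saturated ring such as piperidine or morpholine, or a phenyl ring bearing an amine or a carboxylic acid, would read on the same oxygen.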